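The source may report more compounds than this note shows. Statements on the series, on what has been measured and on what is new or still open speak of the compounds shown alone.

Measured so far:
compound 1 `C[C@@H](Oc1cc2cnn(CCC(=O)O)c2cc1Cl)c1ccccn1` gives 1.7;
compound 2 `C[C@@H](Oc1cc2ccn(CCC(=O)O)c2cc1Cl)c1ccccn1` gives 2.17;
compound 3 `CCc1cc2oc(=O)n(CCC(=O)O)c2cc1Cl` gives 1.94.

These three values come from a physicochemical assay for lipophilicity, read by HPLC, at pH 7.4; on this read-out lower numbers stand for lower lipophilicity and higher numbers for higher lipophilicity. Compound 3 sits between the other two, and its gaps to both compound 1 and compound 2 are within the usual scatter, so no order among the three can be claimed from this assay.

Compound 4 `C[C@@H](Oc1cc2oc(=O)n(CCC(=O)O)c2cc1Cl)c1ncco1` has not yet been measured. It differs from compound 3 in one place: a group of 8 heavy atoms (5 carbon, 1 nitrogen, 2 oxygen; one five-membered aromatic ring with 2 hetero atoms) in place of a group of 2 heavy atoms (2 carbon; no ring), on an aromatic carbon. The entering group brings three hydrogen-bond acceptors where the ethyl had none, which in this assay tends to lower the number. A modest drop is expected, a number 0.34 log units lower from compound 3 to compound 4 (beyond the scatter), a step that could still fall within the scatter. Compound 4 is therefore estimated at 1.6, with a likely range from 1.2 to 2.1.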

Compound 4, distribution coefficient: 1.11
For compound 4 the middle estimate is 0.49 log units above the measured one, and the stated range ends above it.
By their numbers in this assay, from the lowest: compound 4; then compounds 1, 3 and 2 (each within the scatter of the next, the first and the last beyond it).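

At this aromatic carbon, ortho to a chloro group, the substituent clearly matters in this assay: exchanging ethyl for the larger group bearing a five-membered aromatic ring with 2 hetero atoms gives a number 0.83 log units lower from compound 3 to compound 4 (beyond the scatter), beyond the scatter. No measurement at hand explains this step.

On these data alone, it remains open which part of the entering group carries the step: the ring, the defined stereocentre or the chain linking them to the core. A methoxy or phenyl group at the same carbon could help separate these parts.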